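The compounds below may be only part of what the source reports. "The series", "measured", "known", "first", "only" and "open" are said of these compounds alone.

Compounds measured so far:
Compound 1, `O=C1c2ccccc2S(=O)(=O)N1CCCCCCN1CCN(c2ccccc2Cl)CC1`: in an ADME assay on HEK293 cells for displacement of a labelled ligand from 5-hydroxytryptamine receptor 6 (Homo sapiens), read by radioligand binding, with a stated time of 1 h (on this read-out lower numbers stand for stronger inhibition and higher numbers for weaker inhibition), compound 1 gives 459 nM.
Compound 2, `O=C1c2ccccc2S(=O)(=O)N1CCCCCCN1CCN(c2cccc(Cl)c2Cl)CC1`: in this assay compound 2 gives 920 nM.

Within the data shown here, compound 2 stands at the higher of the two numbers, with compound 1 its only neighbour; the step of a 2.0-fold higher number from compound 1 to compound 2 (0.30 log units; within the scatter) lies within the scatter, so the two cannot be ordered. Compound 3, `O=C1c2ccccc2S(=O)(=O)N1CCCCCCN1CCN(c2ccc(Cl)c(Cl)c2)CC1`, keeps the same atoms as compound 2 but arranges them differently: 3,4-dichlorophenyl in place of 2,3-dichlorophenyl on an amine nitrogen in a ring. Among the measured compounds shown here, no measured step moves a chloro from one aromatic carbon to another; the one step available, from compound 1 to compound 2, only adds a chloro and is itself within the scatter. For the measured compounds named here, with that as the sole guide, the step from compound 2 to compound 3 in this assay is expected to be small, a 1.0-fold lower number from compound 2 to compound 3 (0.01 log units; within the scatter), in no particular direction. Compound 3 is therefore estimated at 900 nM, within a range from 300 nM to 2700 nM.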

Compound 3, inhibition constant: 132 nM
Beside the measured number, compound 3's estimate is 6.8-fold (0.83 log units) above it; measured number outside the range, below it.
By their numbers in this assay, from the lowest: compound 3; then compounds 1 and 2 (each within the scatter of the next).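

Among these compounds, the chloro arrangement on the aromatic ring attached to the ring amine nitrogen matters in this assay: with the atoms unchanged, 3,4-dichlorophenyl in place of 2,3-dichlorophenyl gives a 7.0-fold lower number from compound 2 to compound 3 (0.84 log units; beyond the scatter), whereas the one earlier step, which only added a chloro, lay within the scatter. The same group in place of 2-chlorophenyl gives a 3.5-fold lower number from compound 1 to compound 3 (0.54 log units; beyond the scatter), so among these three compounds, 3,4-dichlorophenyl alone stands apart, and the number of chloro atoms does not set the order. No measurement at hand bears on the reason for these steps.

The compounds shown leave open whether methoxy or trifluoromethyl in place of the chloro atoms would give a similar number. They also leave open whether the 3,4-dichlorophenyl result would hold with a shorter or longer chain.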